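The source may report more compounds than this note shows. Statements on the series, on what has been measured and on what is new or still open speak of the compounds shown alone.

Working notes on the series. In a physicochemical assay for solubility, in phosphate buffer, measured as kinetic solubility, at pH 7.4 (a higher number here means a more soluble compound, a lower number a less soluble compound), compound 1 (`CCc1ccccc1-c1nc(CN2CCC(C(=O)NCCCN3C[C@H](C)C[C@H](C)C3)CC2)c(C)o1`) gives 55.9 ug/mL, and compound 2 (`Cc1cccc(C)c1-c1nc(CN2CCC(C(=O)NCCCN3C[C@H](C)C[C@H](C)C3)CC2)c(C)o1`) gives 55.9 ug/mL, so compound 2 stands level with compound 1 at the digits available. Compound 3 (`Cc1cc(C)cc(-c2nc(CN3CCC(C(=O)NCCCN4C[C@H](C)C[C@H](C)C4)CC3)c(C)o2)c1`) keeps the shared core and the same atoms, joined differently: 3,5-dimethylphenyl in place of 2,6-dimethylphenyl on an aromatic carbon. In words, it carries 3,5-dimethylphenyl in place of 2,6-dimethylphenyl on an aromatic carbon of the five-membered aromatic ring with 1 nitrogen and 1 oxygen.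

Among the measured compounds shown here, only one measured step bears on this: no change at the digits printed from compound 1 to compound 2 (within the scatter). That step exchanged 2-ethylphenyl for 2,6-dimethylphenyl at the same place and stayed within the scatter. For the measured compounds named here, no measured compound carries 3,5-dimethylphenyl, so the data give no direct reading of this group, and a single step is thin support. On the evidence of that step from compound 1 to compound 2, no step beyond the scatter is expected in this assay, and no direction is favoured. The expected change is small: a 1.1-fold lower number from compound 2 to compound 3 (0.05 log units; within the scatter). For compound 3 the estimated value is 50 ug/mL, with an expected range of 22 ug/mL to 85 ug/mL.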

Compound 3, solubility: > 71 ug/mL
Compound 3 gave a limit, no number; the forecaster's own chance of this, stated with the estimate: 8%; middle value at least 1.4-fold (0.15 log units) from the limit.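

In this assay compound 3 gives > 71 ug/mL, which is a limit of the assay and not a number: the limit of > 71 ug/mL in this assay, at which 1 of the 3 values shown sits. Exchanging 2,6-dimethylphenyl for 3,5-dimethylphenyl, with the same atoms joined differently, gives an at least 1.2-fold higher number from compound 2 to compound 3 (0.10 log units; that floor lies within the scatter), so this position now has a step with a floor but no upper bound, whereas the earlier step between compound 1 and compound 2 could be read in full. The change from 2-ethylphenyl to 3,5-dimethylphenyl gives an at least 1.2-fold higher number from compound 1 to compound 3 (0.10 log units; that floor lies within the scatter), and with both floors within the scatter, the result shows that neither step lowers the reading but does not establish a real gain for compound 3.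

Going by these compounds, how far compound 3 truly lies from compound 1 and compound 2 stays open, as does whether either step reaches beyond the scatter. Also open, on these data alone, is how this position would respond to a phenyl ring carrying an amine or a carboxylic acid, or to a longer chain than the ethyl of compound 1.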